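One ring swapped on compound 2

The source may report more compounds than this note shows. Statements on the series, on what has been measured and on what is new or still open speak of the compounds shown alone.

Of the compounds shown here, three sharing one core have been tested in a functional assay on HepG2 cells (Homo sapiens) for antiproliferative activity, read by MTT assay, with a stated time of 24 h (a lower number here means a stronger inhibitor, a higher number a weaker inhibitor), so far. Compound 2 (`COc1ccc(/C=C/C(=O)c2ccc(OC)c3c2OC(C)(C)C=C3)c(F)c1`) is the only one to give an actual number (7560 nM). Compound 1 (`COc1ccc(C(=O)/C=C/c2cc(OC)c(OC)c(OC)c2)c2c1C=CC(C)(C)O2`) gives only a limit of the assay (> 10000 nM). Compound 3 (`COc1cc(OC)c(OC)cc1/C=C/C(=O)c1ccc(OC)c2c1OC(C)(C)C=C2`) likewise gives only a limit (> 10000 nM). Compound 2 is therefore the single exact reference point.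

Compound 4 (`COc1ccc(/C=C/C(=O)c2ccc(OC)c3c2OC(C)(C)C=C3)cn1`) has not yet been measured. It carries 6-methoxypyridin-3-yl in place of 2-fluoro-4-methoxyphenyl on a double-bonded chain carbon bound to a double-bonded chain carbon.

Within the data shown here, no measured pair shows what a change of this kind does. The expectation therefore rests on compound 2 alone (7560 nM) and is for little movement, perhaps slightly weaker, but nothing beyond the usual scatter. The step expected is small (a 1.2-fold higher number from compound 2 to compound 4 (0.08 log units; within the scatter)). The value expected for compound 4 is an estimated 9000 nM (range 3500 nM to 22000 nM).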

Compound 4, half-maximal inhibitory concentration: > 10000 nM
Compound 4: no number, only a limit; the forecaster's own chance of this, stated with the estimate: 45%; at least 1.1-fold (0.04 log units) between middle value and limit.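

In this assay, among these compounds, this swap gives the first step that can be read at this position: an at least 1.3-fold higher number from compound 2 to compound 4 (0.12 log units; that floor lies within the scatter). Going by these compounds, compound 4 gives only a limit of the assay, so this step is a floor: replacing 2-fluoro-4-methoxyphenyl with 6-methoxypyridin-3-yl shows no gain in strength, and the true size of any loss remains unknown. Compound 2 still holds the only exact number, and the series now gathers at a single ceiling: the limit of > 10000 nM in this assay, at which 3 of the 4 values shown sit.

The compounds shown cannot separate the loss of the fluorine from the arrival of the ring nitrogen, as a plain 4-methoxyphenyl group would begin to do. They also leave open whether an amine such as dimethylamino, in place of the methoxy group on this ring, would bring a value within the measurable range.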